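Hydroxymethyl to hydroxy swap across two cores

This account rests on a few compounds, and the source may have more. Where it says the series, first, only, none or still open, it means among the compounds named here.

Compound 1 `O=C(Nc1cccc(-c2ccc(CO)cc2)c1)c1ccccc1` carries a hydroxymethyl on its outer ring, and compound 3 `O=C(Nc1cccc(-c2ccc(O)cc2)c1)c1ccccc1` differs from it by hydroxy in place of hydroxymethyl on an aromatic carbon. Compound 2 `CS(=O)(=O)Nc1ccc(-c2ccc(CO)cc2)cc1` shares the hydroxymethyl but sits on another core; the difference between the two cores is not broken down here. Compound 4 `CS(=O)(=O)Nc1ccc(-c2ccc(O)cc2)cc1`, still unmeasured, differs from compound 2 by hydroxy in place of hydroxymethyl on an aromatic carbon, the same change as that between compound 1 and compound 3, with the place described in identical words.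

In an assay for binding affinity to 17-beta-hydroxysteroid dehydrogenase type 1 (Homo sapiens), with a stated time of 20 min, tested at 1 uM (on this read-out higher numbers stand for more inhibition at the one concentration tested (going by the name of the read-out) and lower numbers for less inhibition), compound 1 gives < 10%, which is a limit of the assay and not a number. In this assay compound 3 gives < 10%, again a limit. In this assay compound 2 gives < 10%, also a limit. The step that the two limits leave unreadable from compound 1 to compound 3 cannot be sized because of the limit of < 10% in this assay, at which 3 of the 3 values shown sit.

For compound 4 in this assay the step that the limit leaves unreadable from compound 2 to compound 4 is expected, resting on a step that the two limits leave unreadable from compound 1 to compound 3 and on the limit of compound 2. Compound 4 is therefore estimated at 5%, with a range from 0% to 15%, and the assay is expected to report only its limit once more.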

Compound 4, a percentage reported as inhibition, at one concentration (the size of the read-out at that concentration, not a potency): < 10%
Compound 4: only a limit was reported; the forecaster's own chance of this, stated with the estimate: 85%; the middle value lies beyond the limit too.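

No new step can be read from compound 2 and compound 4, because both stand at the same limit of the assay: the limit of < 10% in this assay, at which 4 of the 4 values shown sit.
The compounds shown leave open whether hydroxy and hydroxymethyl differ at all on either core in this assay, and what would bring any of these compounds off this limit.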